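Two methoxy groups on the urea-linked phenyl ring

The compounds below may be only part of what the source reports. "The series", "measured", "known", "first", "only" and "open" are said of these compounds alone.

Compound 1 `CCCCCCCC/C=C\CCCCCCCCNC(=O)Nc1c(OC)cc(OC)cc1OC`: 320 nM
Compound 2 `CCCCCCCC/C=C\CCCCCCCCNC(=O)Nc1ccccc1`: > 5000 nM
Compound 3 `CCCCCCCC/C=C\CCCCCCCCNC(=O)Nc1ccc(Oc2ccccc2)cc1`: > 5000 nM

All three measured compounds share a long unsaturated chain joined through a urea to an aromatic ring, and were tested in an assay on microsomes from intestinal mucosa for inhibition of acyl-CoA:cholesterol acyltransferase (Oryctolagus cuniculus); on this read-out lower numbers stand for stronger inhibition and higher numbers for weaker inhibition. Compound 1 carries three methoxy groups on that ring and gives 320 nM. Compound 2, with an unsubstituted phenyl ring, gives only > 5000 nM, which is a limit of the assay and not a number. Compound 3 likewise gives only > 5000 nM, again a limit rather than a number. Among the measured compounds shown here, the step that the two limits leave unreadable from compound 2 to compound 3 therefore cannot be read, since the limit of > 5000 nM in this assay, at which 2 of the 3 values shown sit, hides both ends of it; the only measured step in this set gives no usable size.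

Compound 4 `CCCCCCCC/C=C\CCCCCCCCNC(=O)Nc1ccc(OC)cc1OC` is the unmeasured compound. Relative to compound 2 the change is 2,4-dimethoxyphenyl in place of phenyl on an amide-type nitrogen. Compound 1 and compound 2 are not a single listed step, but their two values show that a trimethoxy-bearing ring yields a number while the bare ring stays beyond the limit. With two of those three methoxy groups, compound 4 is expected to fall between them, so the step of an at least 3.3-fold lower number from compound 2 to compound 4 (0.52 log units; beyond the scatter) is expected to be a gain in inhibition that may not fully reach compound 1. Compound 4 is estimated at 1500 nM, within a range from 400 nM to 6000 nM.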

Compound 4, half-maximal inhibitory concentration: 5400 nM
For compound 4 the middle estimate is 3.6-fold (0.56 log units) below the measured one, and the stated range covers the measured number.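

In this assay, among the compounds shown here, hydrogen in place of one methoxy on an aromatic carbon gives a 17-fold higher number from compound 1 to compound 4 (1.23 log units; beyond the scatter), so two methoxy groups on the ring do not keep the inhibition seen with three, and the third methoxy group carries far more weight than the earlier compounds could show. Compound 2 stays at > 5000 nM, which is a limit and not a number. The steps that start from compound 2 therefore cannot be read, and how much the 2,4-dimethoxyphenyl group gains over plain phenyl stays unknown because one end of the comparison is hidden: the limit of > 5000 nM in this assay, at which 2 of the 4 values shown sit.

The compounds shown leave open whether the third group has to be a methoxy at all, since a methyl, a chlorine or an ethoxy on that same aromatic carbon could tell whether a methoxy is specifically needed or whether another group would restore the inhibition. They also leave open how a ring with a single methoxy, or with a dimethylamino group in its place, would compare with compound 4 and compound 1.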